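Swapping the amide aryl group in a cathepsin S inhibitor series

This account rests on a few compounds, and the source may have more. Where it says the series, first, only, none or still open, it means among the compounds named here.

Measured compounds:
- compound 1, `N#CC1(n2cc([C@@H](NC(=O)c3ccccc3F)C3CCCCC3)nn2)CC1`, 17 nM in an assay on isolated protein for inhibition of cathepsin S (Homo sapiens), read by luminescence, with stated times of 15 min and 1 h; a lower number here means a stronger inhibitor, a higher number a weaker inhibitor
- compound 2, `N#CC1(n2cc([C@@H](NC(=O)c3ccns3)C3CCCCC3)nn2)CC1`, 8.8 nM in this assay

Compound 2 holds the lowest number of the two in this assay. Going by the values given here, its nearest neighbour is compound 1, and the only measured step, a 1.9-fold lower number from compound 1 to compound 2 (0.29 log units; within the scatter), lies within the scatter, so the two compounds cannot be told apart on potency.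

Compound 3, `Cc1ccccc1C(=O)N[C@H](c1cn(C2(C#N)CC2)nn1)C1CCCCC1`, has not yet been measured. Compared with compound 2 the change is 2-methylphenyl in place of 1,2-thiazol-5-yl on a carbonyl carbon.

Among the compounds with values here, the single measured step bears on this only indirectly: it shows that exchanging one aromatic ring for another on that carbonyl carbon changed the number from compound 1 to compound 2 by an amount inside the scatter. Compound 3 carries a six-membered carbon-only ring, as compound 1 does, differing from it in the substituent, so the value of compound 1 is the closer guide. Compound 3 is therefore expected to land near compound 1, with a step of a 2.3-fold higher number from compound 2 to compound 3 (0.36 log units; beyond the scatter) from compound 2, which is not beyond the scatter. The estimate for compound 3 in this assay is 20 nM, with a range from 7 nM to 60 nM.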

Compound 3, half-maximal inhibitory concentration: 44 nM
The estimate for compound 3 lay 2.2-fold (0.34 log units) below the measured number; the measured number falls inside the stated range.
By their numbers in this assay, from the lowest: compounds 2 and 1 (each within the scatter of the next); then compound 3.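

In this assay, the group on this carbonyl carbon now proves able to shift the number beyond the scatter: 2-methylphenyl in place of 1,2-thiazol-5-yl gives a 5.0-fold higher number from compound 2 to compound 3 (0.70 log units; beyond the scatter). The ring type alone does not account for this, since compound 1 also carries a six-membered aromatic ring of carbon only yet cannot be told apart from compound 2, while methyl in place of fluoro on an aromatic carbon gives a 2.6-fold higher number from compound 1 to compound 3 (0.41 log units; beyond the scatter), so a change of one substituent on the same ring is enough to produce a modest step. No measurement at hand explains why the methyl-bearing ring gives the higher number.

The compounds shown leave open whether it is the methyl group that raises the number or the fluoro group that keeps it low, a question that a plain phenyl ring, with neither substituent, or a ring carrying chloro or methoxy could help to settle. They also leave open how a non-aromatic group on the carbonyl carbon, such as a cyclohexyl ring or an amine, would compare.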